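From 4-methylpiperidin-1-yl to diethylamino in compound 3

This account rests on a few compounds, and the source may have more. Where it says the series, first, only, none or still open, it means among the compounds named here.

In a functional assay on A549 cells (Homo sapiens) for cytotoxicity, read by MTT assay, with a stated time of 72 h (on this read-out higher numbers stand for weaker inhibition and lower numbers for stronger inhibition), compound 1 (`CCN(CC)Cc1ccc2nc(NC(=O)N/N=C/c3cn(Cc4ccc(C(C)(C)C)cc4)c4ccccc34)sc2c1`) gives 1710 nM and compound 2 (`CC1CCN(Cc2ccc3nc(NC(=O)N/N=C/c4cn(Cc5ccc(Cl)cc5Cl)c5ccccc45)sc3c2)CC1`) gives 3640 nM as the higher of the two numbers. That makes compound 2 the less potent of this pair, by a gap beyond the usual scatter of repeated measurements.

For the measured compounds named here, compound 3 (`CCN(CC)Cc1ccc2nc(NC(=O)N/N=C/c3cn(Cc4ccc(Cl)cc4Cl)c4ccccc34)sc2c1`) has no measurement yet. It differs from compound 2 in one place: diethylamino in place of 4-methylpiperidin-1-yl on a saturated chain carbon bound to an aromatic carbon with diethylamino in place of 4-methylpiperidin-1-yl on a saturated chain carbon bound to an aromatic carbon.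

Going by the values given here, no measured pair shows this exchange on its own, so its size cannot be read directly from the data. Among the compounds with values here, the only hint is that compound 3 shares diethylamino with compound 1 at 1710 nM in the same test, although those two structures differ elsewhere. An estimated 1.5-fold lower number from compound 2 to compound 3 (0.16 log units; within the scatter) in this assay is expected here, a small move toward a lower number that may well stay within the scatter. For compound 3 the expected value is 2500 nM with an estimated range from 1000 nM to 6000 nM around it.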

Compound 3, half-maximal inhibitory concentration: 1900 nM
The estimate for compound 3 lay 1.3-fold (0.12 log units) above the measured number, within the range that was stated.
By their numbers in this assay, from the lowest: compounds 1, 3 and 2 (each within the scatter of the next, the first and the last beyond it).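

In this assay the exchange of 4-methylpiperidin-1-yl for diethylamino on a saturated chain carbon bound to an aromatic carbon can now be read on its own: it gives a 1.9-fold lower number from compound 2 to compound 3 (0.28 log units; within the scatter) and so shows no clear difference between these two amines at this position. The other exchange, 2,4-dichlorophenyl in place of 4-(tert-butyl)phenyl on a saturated chain carbon bound to an aromatic nitrogen, gives a 1.1-fold higher number from compound 1 to compound 3 (0.05 log units; within the scatter) with the diethylamino group held constant, so these two groups cannot be told apart here either. Neither single exchange reaches beyond the scatter, and no outside measurement is available to explain these results.

Still open, from the compounds shown here alone, is whether a ring amine with a second hetero atom, such as morpholin-4-yl or piperazin-1-yl, or a group with no amine at all, such as a carboxylic acid, would give a clear difference on the saturated chain carbon bound to an aromatic carbon. Going by these compounds, it is equally open whether a plain benzyl group or a 4-methoxybenzyl group on the aromatic nitrogen of the shared core would move the number beyond the scatter.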